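Swapping bromine for a dimethyl-isoxazole on a thiophene

The source may hold more compounds than are shown below. What is called first, only, known or untested is meant among the compounds shown, and "the series" means these compounds.

Among the measured compounds shown here, compound 2 `CC(C)(C)Cc1c(Br)sc(N)c1C(=O)c1ccc(Cl)cc1` is tested in an assay on CHO cells for displacement of a labelled ligand from adenosine receptor A3 (Homo sapiens), read by scintillation counting, tested at 10 uM (a higher number here means more inhibition at the concentration tested (going by the name of the read-out), a lower number less inhibition), and gives 1%, the lower of the two numbers known, though its neighbour compound 1 `CC(C)(C)Cc1csc(N)c1C(=O)c1ccc(Cl)cc1` gives 5%, a difference within the scatter. Compound 3 `Cc1noc(C)c1-c1sc(N)c(C(=O)c2ccc(Cl)cc2)c1CC(C)(C)C` carries 3,5-dimethyl-1,2-oxazol-4-yl in place of bromo on an aromatic carbon. For the measured compounds named here, the only measured step, a number 4 percentage points lower from compound 1 to compound 2 (within the scatter), concerns a different substitution at the same carbon and shows no real movement. Nothing measured speaks to the new group itself. Compound 3 is therefore expected to show no step beyond the scatter, a number 2 percentage points higher from compound 2 to compound 3 (within the scatter). The estimate for compound 3 is 3%, with a range from -10% to 20%.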

Compound 3, a percentage reported as inhibition, at one concentration (the size of the read-out at that concentration, not a potency): 1%
For compound 3 the middle estimate is 2 percentage points above the measured one, and the stated range covers the measured number.
By their numbers in this assay, from the lowest: compounds 2, 3 and 1 (each within the scatter of the next).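

In this assay, swapping bromo for 3,5-dimethyl-1,2-oxazol-4-yl gives no change at the digits printed from compound 2 to compound 3 (within the scatter) and putting that same group in place of hydrogen gives a number 4 percentage points lower from compound 1 to compound 3 (within the scatter), so a whole aromatic ring on this carbon, next to the ring sulfur, leaves the number where hydrogen and bromo had it. All three numbers are low, so this change shows no gain, and a further fall would have little room to appear. Nothing available explains this result.

As far as these compounds go, whether an amine or a carboxylic acid on this carbon would raise the number remains open. So does whether replacing the neopentyl group with a longer chain would do so.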